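The compounds below may be only part of what the source reports. "The series", "measured", "known", "first", "only" and "open" are said of these compounds alone.

Compound 1 `OCC(O)COc1nc(N2CCCCC2)c2nc(OC[C@H](O)CO)nc(N3CCCCC3)c2n1` and compound 2 `C[C@H](O)COc1nc(N2CCCCC2)c2nc(OC[C@@H](C)O)nc(N3CCCCC3)c2n1` are built on the same core, each carrying two identical side chains through oxygen. Among the compounds with values here, in a functional assay on L1210 cells (Mus musculus) for inhibition, read by thymidine incorporation, tested at 10 uM (on this read-out higher numbers stand for a stronger effect at the one concentration tested and lower numbers for a weaker effect), compound 1 gives 32%, the lower of the two numbers measured so far. Compound 2 gives 92% in this assay, a gap to compound 1 that lies well beyond the usual scatter of repeated measurements.

Compound 3 `OCC(O)COc1nc(N2CCCCC2)c2nc(OC[C@@H](O)CO)nc(N3CCCCC3)c2n1` has not yet been tested. Set against compound 1, the change is this: the two compounds have the same atoms and bonds; at least one stereo element is drawn with a configuration in one of them and without one in the other: 1 of 2 stereo elements differ; a stereocentre at a saturated chain carbon is drawn R in compound 1 and S in compound 3. No atoms leave or enter; only the drawn configuration at that one chain carbon is reversed. Within the data shown here, with no measured pair of this kind to lean on, the step from compound 1 is expected to be small, in either direction, and most likely not beyond the scatter.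

Compound 3 is therefore expected to reach about 35% in this assay, somewhere between 10% and 65%, which corresponds to an expected step of a number 3 percentage points higher from compound 1 to compound 3 (within the scatter).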

Compound 3, a percentage reported as inhibition, at one concentration (the size of the read-out at that concentration, not a potency): 37%
Beside the measured number, compound 3's estimate is 2 percentage points below it; measured number inside the range.
By their numbers in this assay, from the lowest: compounds 1 and 3 (each within the scatter of the next); then compound 2.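

Reversing the drawn configuration at this one chain carbon now has a measured step: this assay records a number 5 percentage points higher from compound 1 to compound 3 (within the scatter). At this place in the side chain, then, the change leaves no mark that can be told apart from the scatter, at the one concentration tested. This reading needs one caution, since the comparison rests on how the two structures are drawn: the fact that one of compounds 1 and 3 is drawn with a defined configuration and the other without, at the place where they differ

The compounds shown leave open whether a drawn configuration at the other side chain would matter any more than this one does. They also leave open how the read-out would respond if an amine or a carboxylic acid stood in place of the hydroxyl groups on these chains, or if a longer chain carried them.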